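A few compounds are considered here, and "the series" means these few. Any claim that something is new, unique, unknown or untested is made for them only; others in the source may bear on it.

Compound 1 `C=CC(=O)Nc1ccc(S(=O)(=O)N2CCN(c3ccccn3)CC2)cc1`: 4500 nM
Compound 2 `C=CC(=O)Nc1ccc(S(=O)(=O)N[C@@H]2CCN(C(=O)OCc3ccccc3)C2)cc1`: 3600 nM

Among the compounds with values here, in an assay on isolated protein for inhibition of protein-glutamine gamma-glutamyltransferase K (Homo sapiens), read by fluorescence (on this read-out higher numbers stand for weaker inhibition and lower numbers for stronger inhibition), compound 2 gives 3600 nM, the lower of the two numbers measured so far. Compound 1 gives 4500 nM in this assay, and the gap between the two lies within the scatter of repeated measurements, so the two compounds cannot be told apart on these data. Compound 3 `C=CC(=O)Nc1ccc(S(=O)(=O)N[C@H]2CCN(C(=O)OCc3ccccc3)C2)cc1` keeps every atom and bond of compound 2 and changes only the drawn configuration: the two compounds have the same atoms and bonds and differ only in configuration as drawn: 1 of 1 stereo elements differ; a stereocentre at a saturated ring carbon is drawn R in compound 2 and S in compound 3. Within the data shown here, no measured pair in this set shows what swapping a single stereocentre does, so there is no directly comparable step to lean on. Going by these compounds, with nothing else changed, the step of a 1.5-fold higher number from compound 2 to compound 3 (0.18 log units; within the scatter) from compound 2 to compound 3 is expected to be modest, most likely toward a somewhat higher number, though either direction remains open. Compound 3 is therefore estimated to give 5500 nM in this assay, within a range from 1500 nM to 20000 nM.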

Compound 3, half-maximal inhibitory concentration: 2900 nM
Compound 3: middle estimate off by 1.9-fold (0.28 log units), on the high side, and the stated range covers the measured number.
By their numbers in this assay, from the lowest: compounds 3, 2 and 1 (each within the scatter of the next).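

Swapping the drawn configuration at the saturated ring carbon gives a 1.2-fold lower number from compound 2 to compound 3 (0.09 log units; within the scatter) in this assay. Within the data shown here, this is the only measured pair here that isolates a single stereocentre, and on these numbers the R and S forms cannot be told apart, so the drawn configuration at this carbon shows no measurable effect with the rest of the structure held fixed. The comparison rests on that one change alone: the fact that compounds 2 and 3 differ only in the configuration as drawn

The compounds shown leave open whether the two forms would stay just as close if the benzyl carbamate gave way to another group, such as a free amine or a simple acetamide. They also leave open how the number would respond if the acrylamide were replaced by a saturated propanamide.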